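The source may hold more compounds than are shown below. What is called first, only, known or untested is meant among the compounds shown, and "the series" means these compounds.

Compound 1 (`CC(C)(C)NCc1c(C(=O)O)nn(-c2ccccc2)c1-c1ccc(F)cc1`) and compound 2 (`CC(C)(C)NCc1c(C(=O)O)nn(-c2ccc(Cl)cc2)c1-c1ccc(F)cc1`) share one core and were both tested in a functional assay on PC-3 cells (Homo sapiens) for inhibition, read by sulforhodamine B assay, with a stated time of 48 h; on this read-out lower numbers stand for stronger inhibition of growth and higher numbers for weaker inhibition of growth. Compound 1 gives > 680000 nM, which is a limit of the assay and not a number. On these data alone, compound 2 gives > 623000 nM, which is also a limit, so its true position remains unknown. For the measured compounds named here, the only measured step, chloro in place of hydrogen on an aromatic carbon, is a step that the two limits leave unreadable from compound 1 to compound 2, and it offers no size to carry forward. Compound 3 (`CC(C)(C)NCc1c(C(=O)O)nn(-c2ccc(Cl)cc2)c1-c1ccc([N+](=O)[O-])cc1`) has nitro in place of fluoro on an aromatic carbon, turning 4-fluorophenyl into 4-nitrophenyl: nitro in place of fluoro on an aromatic carbon. Going by the values given here, no measured step covers this change, so the expectation in this assay is no shift beyond the scatter, and another limit is likely. The estimated step is an at least 1.1-fold lower number from compound 2 to compound 3 (0.05 log units; that floor lies within the scatter). For compound 3 the estimated value is 550000 nM, with an expected range of 200000 nM to 800000 nM.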

Compound 3, concentration for 50% growth inhibition: > 583000 nM
Compound 3 ended at the assay's limit (the forecaster's own chance of this, stated with the estimate: 75%); middle value at least 1.0-fold (0.02 log units) away from the limit.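

Compound 2 and compound 3 both end at limits and not at numbers, and the step between them cannot be read. The compounds shown leave open whether any change on the shared core gives a readable value for inhibition of growth.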